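One Chloro Fewer: From Compound 2 to Compound 4

This account rests on a few compounds, and the source may have more. Where it says the series, first, only, none or still open, it means among the compounds named here.

Of the compounds shown here, three built on a shared core have been measured so far in a functional assay on HCT-116 cells (Homo sapiens) for antiproliferative activity, read by MTT assay, with a stated time of 72 h (a higher number here means a weaker inhibitor, a lower number a stronger inhibitor), and they give a first picture. Compound 1 (`COc1cc(CCc2ccccn2)cc(OC)c1O`) gives 3060 nM there. Compound 2 (`COc1cc(CCc2ccc(Cl)c(Cl)c2)cc(OC)c1O`) gives 1860 nM and compound 3 (`COc1cc(CCc2cccc(F)c2)cc(OC)c1O`) gives 7570 nM in the same test. Compound 2 stands at the low, stronger end of these numbers together with compound 1, the two lying within the usual scatter of each other. Compound 3 lies beyond the scatter from compound 2 on the weaker side.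

Compound 4 (`COc1cc(CCc2ccc(Cl)cc2)cc(OC)c1O`) has not been measured yet. It differs from compound 2 in one place: hydrogen in place of chloro on an aromatic carbon which in words is hydrogen in place of chloro on an aromatic carbon. For the measured compounds named here, no two measured compounds differ in just one place, so no direct step is available as a guide. Compound 3 carries fluoro rather than chloro and gives 7570 nM as its number, a loose hint only, since it differs from compound 2 in more than that. The expected change is a 1.8-fold higher number from compound 2 to compound 4 (0.26 log units; within the scatter) in this assay as a modest move toward a weaker inhibitor that may stay within the scatter. The estimated value for compound 4 is 3400 nM with an expected range from 1500 nM to 7500 nM for now.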

Compound 4, half-maximal inhibitory concentration: 330 nM
Estimate against measurement, compound 4: 10-fold (1.01 log units) above; measured number below the stated range.
By their numbers in this assay, from the lowest: compound 4; then compounds 2 and 1 (each within the scatter of the next); then compound 3.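

In this assay, for the compounds shown here, this pair gives the first direct reading of a single change on the shared core: replacing with hydrogen the chloro that sits ortho to a chloro group and meta to a large group gives a 5.6-fold lower number from compound 2 to compound 4 (0.75 log units; beyond the scatter). The aromatic carbon carrying that chloro therefore matters in this test, and the second chloro is not needed for a low number, since the ring with one chloro gives a stronger inhibitor than the ring with two. Within this pair, then, more chlorine on the ring does not go with stronger inhibition, although nothing available here explains why losing this one heavy atom lowers the number.

This single pair cannot show whether the effect of removing this chloro depends on the chloro that stays, or whether it would hold on a ring carrying a different remaining group such as bromo. It also leaves open whether a methyl, a nitrile or an amine on the same aromatic carbon would give a number as low as hydrogen does.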